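This account rests on a few compounds, and the source may have more. Where it says the series, first, only, none or still open, it means among the compounds named here.

Of the compounds shown here, two sharing one core have so far been tested in a functional assay on MDA-MB-468 cells (Homo sapiens) for cytotoxicity, with a stated time of 48 h; on this read-out lower numbers stand for stronger inhibition and higher numbers for weaker inhibition. Compound 1 `O=[N+]([O-])c1ccc(CN2CCC(n3cc(CC(OCc4cc(-c5ccccc5)no4)c4ccc(Br)cc4)nn3)CC2)cc1` gives 3000 nM, and compound 2 `O=[N+]([O-])c1ccc(CN2CCC(n3cc(CC(OCc4cc(-c5ccc(Br)cc5)no4)c4ccc(Br)cc4)nn3)CC2)cc1` gives 5000 nM. Compound 2 has the higher of the two numbers, yet the step of a 1.7-fold higher number from compound 1 to compound 2 (0.22 log units; within the scatter) lies within the scatter, so the two compounds cannot be told apart on this read-out. Compound 3 `O=[N+]([O-])c1ccc(CN2CCC(n3cc(CC(OCc4cc(-c5ccc(F)cc5)no4)c4ccc(Br)cc4)nn3)CC2)cc1` is not yet measured. It differs from compound 2 in one place: fluoro in place of bromo on an aromatic carbon. Going by the values given here, the only measured step that touches this position is a 1.7-fold higher number from compound 1 to compound 2 (0.22 log units; within the scatter), which put a bromo where hydrogen had been and hardly moved the number. A halogen at this place having made so little difference, swapping one halogen for another is expected to make little difference as well, so the expected step of a 1.3-fold lower number from compound 2 to compound 3 (0.10 log units; within the scatter) stays within the scatter. Compound 3 is therefore estimated at 4000 nM, with a range from 1800 nM to 9000 nM.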

Compound 3, half-maximal inhibitory concentration: 4000 nM
Compound 3: the middle estimate sits on the measured number at the digits printed; low and high end bracket the measured number.
By their numbers in this assay, from the lowest: compounds 1, 3 and 2 (each within the scatter of the next).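

In this assay, the change of one halogen for another gives a 1.3-fold lower number from compound 2 to compound 3 (0.10 log units; within the scatter), and fluoro in place of hydrogen gives a 1.3-fold higher number from compound 1 to compound 3 (0.12 log units; within the scatter). This position has now carried hydrogen, bromo and fluoro, and the three compounds cannot be told apart on this read-out, whereas the earlier pair covered only hydrogen and bromo. No measurement available here offers an explanation for this flat result.

The compounds shown leave open whether the number would hold with a group other than a halogen at this place, such as an amine, a carboxylic acid or a longer chain. They also leave open whether any change elsewhere on the shared core would move the number beyond the scatter.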